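Shortening the chain: from compound 2 to compound 4

The source may report more compounds than this note shows. Statements on the series, on what has been measured and on what is new or still open speak of the compounds shown alone.

Measured so far in a physicochemical assay for lipophilicity, in phosphate buffer, measured as octanol-water partition, at pH 11.5; a lower number here means a more polar compound, a higher number a more lipophilic compound
- compound 1 `CCCCCCCCCCCCNC(=N)NC(=N)Nc1ccc(Cl)cc1` gives 7.13
- compound 2 `CCCCCCCCNC(=N)NC(=N)Nc1ccc(Cl)cc1` gives 5.13
- compound 3 `CCCCCCCCNC(=N)NC(=N)Nc1ccc(OC)cc1` gives 4.41

Compound 2 with 5.13 holds the middle place of the three numbers, below compound 1 and above compound 3, with both gaps beyond the scatter. Compound 4 `CNC(=N)NC(=N)Nc1ccc(Cl)cc1` is not yet measured. It carries hydrogen in place of heptyl on a saturated chain carbon bound to an amine nitrogen.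

The measured step closest to this change is a number 2.00 log units lower from compound 1 to compound 2 (beyond the scatter), where hydrogen replaces butyl on the chain. Going by the values given here, it is the only chain step available, so the trend rests on one pair. The other measured step, a number 0.72 log units lower from compound 2 to compound 3 (beyond the scatter), concerns methoxy in place of chloro on an aromatic carbon and does not bear on this change. Heptyl is a longer group than butyl, so a larger step in the same direction is expected, provided the chain trend continues this far. The expected step is a number 3.43 log units lower from compound 2 to compound 4 (beyond the scatter), and it is an estimate from that single pair. In this assay compound 4 is therefore estimated at 1.7, with an expected range from 1 to 2.4.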

Compound 4, partition coefficient: 1.58
For compound 4 the middle estimate is 0.12 log units above the measured one; measured number inside the range.
By their numbers in this assay, from the lowest: compound 4; then compound 3; then compound 2; then compound 1.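

In this assay, going by these compounds alone, hydrogen in place of heptyl on a saturated chain carbon bound to an amine nitrogen gives a number 3.55 log units lower from compound 2 to compound 4 (beyond the scatter), which carries the chain trend well beyond the single earlier pair. Together with a number 2.00 log units lower from compound 1 to compound 2 (beyond the scatter), this gives two steps in the same direction, so compound 1, compound 2 and compound 4 now fall in order as the chain shortens, with none of the three going against that order. Nothing available explains the size of the new step or separates the contribution of each chain carbon.

From the compounds shown here alone, both chain steps are read with chloro on the aromatic carbon, so it remains open whether a similar step would appear with methoxy, as carried by compound 3. Going by these compounds, it also remains open whether the order depends only on chain length, which a branched chain, a chain ending in a hydroxyl group or an amine, or a cyclohexyl group in place of heptyl could test at this position.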